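Cyclopropylcarbamoyl to (Pyrrolidin-1-yl)carbonyl on a Shared Core

The source may hold more compounds than are shown below. What is called first, only, known or untested is meant among the compounds shown, and "the series" means these compounds.

Of the compounds shown here, three of one series have been measured in a functional assay on HCT-116 cells (Homo sapiens) for cytotoxicity, read by MTT assay, with a stated time of 48 h; on this read-out higher numbers stand for weaker inhibition and lower numbers for stronger inhibition. Compound 1 `CC(C)NC(=O)c1cc(Oc2cccc(NC(=S)Nc3ccc(Cl)cc3)c2)ccn1` gives 22100 nM, compound 2 `CNC(=O)c1cc(Oc2cccc(NC(=S)Nc3ccc(F)c(F)c3)c2)ccn1` gives 30300 nM, and compound 3 `O=C(NC1CC1)c1cc(Oc2cccc(NC(=S)Nc3cccc(C(F)(F)F)c3)c2)ccn1` gives 20200 nM. Compound 3 has the lowest of the three numbers, but its nearest neighbour, compound 1, lies within the scatter, and even compound 2, the furthest, is still within the scatter. Going by the values given here, the three values therefore form one cluster, and no compound can be set apart from the others on these numbers.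

Compound 4 `O=C(c1cc(Oc2cccc(NC(=S)Nc3cccc(C(F)(F)F)c3)c2)ccn1)N1CCCC1` is built from compound 3 by one change: pyrrolidin-1-yl in place of cyclopropylamino on a carbonyl carbon. The amide hydrogen of the cyclopropylcarbamoyl group is lost along with the cyclopropylamino group, and the (pyrrolidin-1-yl)carbonyl group takes its place, while the rest of compound 3 is unchanged. Among the compounds with values here, no measured pair in this set reports what such an exchange does, and the three values give no hint that the amide end moves the read-out beyond the scatter. Compound 4 is therefore expected to land close to compound 3, with an expected step of a 1.2-fold higher number from compound 3 to compound 4 (0.09 log units; within the scatter), and an estimated value of 25000 nM, ranging from 10000 nM to 60000 nM.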

Compound 4, half-maximal inhibitory concentration: 19200 nM
Compound 4: the middle estimate sits 1.3-fold (0.11 log units) above what was measured; measured number inside the range.
By their numbers in this assay, from the lowest: compounds 4, 3, 1 and 2 (each within the scatter of the next).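

In this assay the exchange of cyclopropylamino for pyrrolidin-1-yl on a carbonyl carbon comes to a 1.1-fold lower number from compound 3 to compound 4 (0.02 log units; within the scatter) and gives the series its first comparison between compounds that differ in one place. It shows that, with the rest of compound 3 unchanged, the amide hydrogen can be lost and the three-membered ring replaced by a five-membered ring without the number moving beyond the scatter, so this one exchange leaves the cytotoxicity read-out where it was. Nothing measured here explains why the read-out stays put, and no supporting data on either group bear on this result.

Steps from compound 1 or compound 2 to the other compounds cannot be read, since those compounds differ from them in more than one place, so the part played by the other end of the molecule remains unknown. As far as these compounds go, it also remains open whether any group on this carbonyl carbon can move the number beyond the scatter, for instance a morpholin-4-yl ring, a piperazin-1-yl ring with its free amine, a longer alkyl chain on the amide nitrogen, or a carboxylic acid in place of the amide.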